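The source may hold more compounds than are shown below. What is called first, only, known or untested is meant among the compounds shown, and "the series" means these compounds.

Measured compounds:
compound 1, `CC(Cl)CC(=O)NC1=C(C#N)C(c2ccc(Cl)cc2Cl)C2=C(CCCC2=O)N1c1ccc(S(N)(=O)=O)cc1`: 60%
compound 2, `N#CC1=C(NC(=O)c2ccc([N+](=O)[O-])cc2)N(c2ccc(S(N)(=O)=O)cc2)C2=C(C(=O)CCC2)C1c1ccc(Cl)cc1Cl`: 70%

In a functional assay on Ehrlich cells (Mus musculus) for cytotoxicity, read by trypan blue exclusion, with a stated time of 2 h, tested at 100 ug/mL (a lower number here means a weaker effect, a higher number a stronger effect of the compound at the concentration tested), compound 1 gives 60% and compound 2 gives 70%; the step of a number 10 percentage points higher from compound 1 to compound 2 (within the scatter) lies within the scatter, so the two cannot be ranked. Compound 3 `CCO/C=N/C1=C(C#N)C(c2ccc(Cl)cc2Cl)C2=C(CCCC2=O)N1c1ccc(S(N)(=O)=O)cc1` differs from compound 1 by a group of 5 heavy atoms (3 carbon, 1 nitrogen, 1 oxygen; no ring) in place of a group of 7 heavy atoms (4 carbon, 1 nitrogen, 1 oxygen, 1 chlorine; no ring), on a double-bonded ring carbon. Among the compounds with values here, only the step from compound 1 to compound 2 bears on this change, and it too touched the group on the carbonyl carbon without moving the number beyond the scatter. Compound 3 is therefore expected to shift by no more than no change at the digits printed from compound 1 to compound 3 (within the scatter). The estimate for compound 3 is 60%, expected between 45% and 75%.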

Compound 3, a percentage reported as activity, at one concentration (the size of the read-out at that concentration, not a potency): 40%
Beside the measured number, compound 3's estimate is 20 percentage points above it; measured number outside the range, below it.
By their numbers in this assay, from the lowest: compound 3; then compounds 1 and 2 (each within the scatter of the next).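

The position is not indifferent to what it carries: in this assay, changing the group gives a number 20 percentage points lower from compound 1 to compound 3 (beyond the scatter), and a number 30 percentage points lower from compound 2 to compound 3 (beyond the scatter), whereas the earlier step stayed within the scatter. The entering group has 0 hydrogen-bond donors, while the ((2-chloropropyl)carbonyl)amino group it replaces has 1, but this is only a count and does not establish a link to the lower number. No measurement here explains the drop. Still open, as far as these compounds go, is how a plain amine on this double-bonded ring carbon would compare, and whether a longer alkoxy chain in the entering group would change the number.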